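This account rests on a few compounds, and the source may have more. Where it says the series, first, only, none or still open, it means among the compounds named here.

In an ADME assay on NIH3T3 cells (Mus musculus) for cytotoxicity (on this read-out higher numbers stand for an effect only at larger amounts of compound and lower numbers for an effect already at smaller amounts), compound 1 (`Cc1cc(Oc2cccc(Cn3ccnn3)c2)cc(C)c1Cl`) gives 66800 nM and compound 3 (`Cc1cc(Oc2cccc(Cn3cnc4ccccc43)c2)cc(C)c1Cl`) gives 40000 nM. Compound 2 (`Cc1cc(Oc2cccc(Cn3cccn3)c2)cc(C)c1Cl`) gives > 100000 nM, which is a limit of the assay and not a number.

Compound 4 (`Cc1nnc(-c2cccc(Oc3cc(C)c(Cl)c(C)c3)c2)o1`) differs from compound 2 in one place: 5-methyl-1,3,4-oxadiazol-2-yl in place of (1H-pyrazol-1-yl)methyl on an aromatic carbon. The 5-methyl-1,3,4-oxadiazol-2-yl group thus stands on an aromatic carbon, where (1H-pyrazol-1-yl)methyl stood before. For the measured compounds named here, the one measured step that bears on this is an at least 1.4-fold higher number from compound 1 to compound 2 (0.17 log units; that floor lies within the scatter). It exchanges one ring for another on the saturated chain carbon, a carbon that compound 4 no longer carries, so it offers only a loose guide. The other guide is that compound 1 at 66800 nM and compound 3 at 40000 nM both return numbers with other groups in that place.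

A modest move toward a lower number is therefore expected, and the expected step is an at least 1.4-fold lower number from compound 2 to compound 4 (0.15 log units; that floor lies within the scatter). For compound 4 the estimated value is 70000 nM, with an expected range of 30000 nM to 100000 nM.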

Compound 4, half-maximal effective concentration: 46100 nM
Compound 4: middle estimate off by 1.5-fold (0.18 log units), on the high side, and the stated range covers the measured number.
By their numbers in this assay, from the lowest: compounds 3, 4 and 1 (each within the scatter of the next). At a limit, above all of these: compound 2.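

In this assay, the aromatic carbon that carried the (1H-pyrazol-1-yl)methyl group also gives a measurable number with a five-membered aromatic ring set on it directly, with no saturated chain carbon in between. Measured against the two chain-linked groups, 5-methyl-1,3,4-oxadiazol-2-yl gives an at least 2.1-fold lower number from compound 2 to compound 4 (0.33 log units; beyond the scatter), and a 1.4-fold lower number from compound 1 to compound 4 (0.16 log units; within the scatter). Only the first of these steps clears the scatter, and its size is only a floor because compound 2 sits at a limit of the assay: the limit of > 100000 nM in this assay, at which 1 of the 4 values shown sits.

The compounds shown leave open whether the change from compound 2 to compound 4 belongs to the new ring or to the loss of the chain carbon, as both change together. They also leave open how an amine or a carboxylic acid at this aromatic carbon would read in this assay.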